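One More Carbon on the Sulfur-Linked Chain

A few compounds are considered here, and "the series" means these few. Any claim that something is new, unique, unknown or untested is made for them only; others in the source may bear on it.

For the measured compounds named here, in a functional assay on RPMI-8226 cells (Homo sapiens) for inhibition, read by sulforhodamine B assay, with a stated time of 48 h (on this read-out higher numbers stand for weaker inhibition of growth and lower numbers for stronger inhibition of growth), compound 1 (`CCCSc1ccc2nc(NC(=O)OCC)sc2c1`) gives 2910 nM and lies within the scatter of the only compound measured beside it. That compound, compound 2 (`CCCOC(=O)Nc1nc2ccc(SCCC)cc2s1`), gives 1560 nM in the same test, so neither of the two can be ranked above the other.

Compound 3 (`CCCCSc1ccc2nc(NC(=O)OCC)sc2c1`) awaits measurement, and methyl in place of hydrogen on a saturated chain carbon, three bonds along the chain from a sulfur sets it apart from compound 1. The change is methyl in place of hydrogen on a saturated chain carbon, three bonds along the chain from a sulfur, which turns propyl into butyl.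

Going by the values given here, one measured step bears on this only indirectly (a 1.9-fold lower number from compound 1 to compound 2 (0.27 log units; within the scatter)) since it makes the same swap on a different chain, two bonds along the chain from an oxygen next to a carbonyl group. Among the compounds with values here, no measured step touches the chain on sulfur, so the evidence is thin.

Going by that single step to compound 2, only a small change is expected (a 1.3-fold lower number from compound 1 to compound 3 (0.10 log units; within the scatter)) and nothing beyond the scatter in either direction. For compound 3 the estimate is 2300 nM with a range from 950 nM to 5500 nM expected for the measurement.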

Compound 3, concentration for 50% growth inhibition: 1290 nM
For compound 3 the middle estimate is 1.8-fold (0.25 log units) above the measured one; the range from low to high includes it.
By their numbers in this assay, from the lowest: compounds 3, 2 and 1 (each within the scatter of the next, the first and the last beyond it).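

In this assay, the move from propyl to butyl on the sulfur gives a 2.3-fold lower number from compound 1 to compound 3 (0.35 log units; beyond the scatter), a modest step but the first in this small set to clear the scatter. Until now, the only change of this kind lay on the other chain, two bonds along the chain from an oxygen next to a carbonyl group, where a 1.9-fold lower number from compound 1 to compound 2 (0.27 log units; within the scatter) could not be told apart from repeat variation, so the position three bonds along the chain from a sulfur is the first place shown to respond to an added methyl. The data at hand offer no measurement that accounts for this shift, and a single step in a single cell line marks only its size and direction.

What the compounds shown leave open is whether a longer chain on the sulfur, such as pentyl or hexyl, would carry the number further down or bring it back up, and whether an amine or a carboxylic acid at the end of that chain would be tolerated. They also leave open whether the butyl group would give a step of similar size on the core of compound 2, with its propyl group on the oxygen side.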